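Swapping the aryl group on a sulfonamide nitrogen

A few compounds are considered here, and "the series" means these few. Any claim that something is new, unique, unknown or untested is made for them only; others in the source may bear on it.

Three compounds share one core, an arylsulfonamide bearing a cyclopropyl-substituted oxazole, and differ only in the aryl group on the sulfonamide nitrogen. Compound 1 `O=S(=O)(Nc1ccc(Cl)cc1Cl)c1ccc(-c2cnc(C3CC3)o2)cc1` carries a 2,4-dichlorophenyl there; in a functional assay on cells (leukaemia cell line, Homo sapiens) for inhibition, read by sulforhodamine B assay, with a stated time of 48 h (on this read-out lower numbers stand for stronger inhibition of growth and higher numbers for weaker inhibition of growth), compound 1 gives 481 nM, the highest of the three numbers, though every gap to the others falls within the scatter. Compound 2 `O=S(=O)(Nc1ccc(F)c(Cl)c1)c1ccc(-c2cnc(C3CC3)o2)cc1` gives 260 nM, and compound 3 `Cc1ccc(NS(=O)(=O)c2ccc(-c3cnc(C4CC4)o3)cc2)cc1C` gives 420 nM.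

Compound 4 `O=S(=O)(Nc1ccc(I)c(Cl)c1)c1ccc(-c2cnc(C3CC3)o2)cc1` is not yet measured. Relative to compound 1 it changes as follows: 3-chloro-4-iodophenyl in place of 2,4-dichlorophenyl on a sulfonamide nitrogen

Going by the values given here, two measured steps bear on this change, since both also swap the aryl group from the 2,4-dichlorophenyl of compound 1: a 1.9-fold lower number from compound 1 to compound 2 (0.27 log units; within the scatter), and a 1.1-fold lower number from compound 1 to compound 3 (0.06 log units; within the scatter). Neither step exceeds the scatter. The step from compound 2 to compound 3 is likewise small: a 1.6-fold higher number from compound 2 to compound 3 (0.21 log units; within the scatter). Among the compounds with values here, no measured compound carries an iodine, so the data say nothing specific about that atom.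

Given that all three aryl swaps left the numbers within the scatter of each other, the estimated step for compound 4 is a 1.5-fold lower number from compound 1 to compound 4 (0.18 log units; within the scatter), leaning slightly toward the side seen for compound 2. Compound 4 is therefore expected to give about 320 nM in this assay, with a range from 120 nM to 850 nM.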

Compound 4, concentration for 50% growth inhibition: 1010 nM
Compound 4: middle estimate off by 3.2-fold (0.50 log units), on the low side; the measured number lies above the stated range.
By their numbers in this assay, from the lowest: compounds 2, 3 and 1 (each within the scatter of the next); then compound 4.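

In this assay this position proves not to be indifferent to the aryl group: the earlier swaps on the sulfonamide nitrogen all stayed within the scatter, whereas 3-chloro-4-iodophenyl gives a 2.1-fold higher number from compound 1 to compound 4 (0.32 log units; beyond the scatter) and a 2.4-fold higher number from compound 3 to compound 4 (0.38 log units; beyond the scatter) as steps that lie beyond it. The most telling comparison is the one confined to a single atom, iodo in place of fluoro on an aromatic carbon, which gives a 3.9-fold higher number from compound 2 to compound 4 (0.59 log units; beyond the scatter) and is the largest step in the set, making compound 4 the weakest of the four at inhibiting growth. The data shown offer no explanation for this loss of growth inhibition.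

Going by these compounds alone, compound 4 is the only iodine-bearing compound, so it remains open whether this step belongs to iodine alone or would also appear with bromo or chloro on the same aromatic carbon. From the compounds shown here alone, how a methoxy group, an amine or a carboxylic acid would read there is also open, as is whether iodo would give a similar step with the other aryl patterns seen here.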